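Exchanging One Ring Group on Compound 2

The compounds below may be only part of what the source reports. "The series", "measured", "known", "first", "only" and "open" are said of these compounds alone.

In a functional assay on HepG2 cells (Homo sapiens) for inhibition, read by sulforhodamine B assay, with a stated time of 3 days (on this read-out higher numbers stand for weaker inhibition and lower numbers for stronger inhibition), compound 1 `O=C1Nc2ccc(F)cc2/C1=C\C(=O)c1ccc(O)cc1F` gives 3440 nM while compound 2 `COc1ccc(C(=O)Nc2ccc3c(c2)/C(=C/Nc2cccc(N4CCN(C)CC4)c2)C(=O)N3)cc1` gives 1780 nM and these two numbers lie within the usual scatter of each other. Compound 2 therefore cannot be told apart from compound 1 on these data.

Compound 3 `CN1CCN(c2cccc(N/C=C3\C(=O)Nc4ccc(NC(=O)c5c(Cl)cccc5Cl)cc43)c2)CC1` has not yet been measured in this assay and differs from compound 2 in one place: 2,6-dichlorophenyl in place of 4-methoxyphenyl on a carbonyl carbon with 2,6-dichlorophenyl in place of 4-methoxyphenyl on a carbonyl carbon. The rest of the structure stays the same.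

Among the measured compounds shown here, no measured pair of compounds shows a change of this kind, so the data give no direct guide to its effect. With so little to go on, a shift beyond the scatter is not expected, and compound 2 at 1780 nM serves as the starting point for the expectation. The estimated step is a 1.2-fold lower number from compound 2 to compound 3 (0.07 log units; within the scatter) and it stays within the scatter. For compound 3 the expected value is 1500 nM with an estimated range from 450 nM to 5000 nM in this wide window.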

Compound 3, half-maximal inhibitory concentration: 2370 nM
Compound 3: the middle estimate sits 1.6-fold (0.20 log units) below what was measured; the measured number falls inside the stated range.
By their numbers in this assay, from the lowest: compounds 2, 3 and 1 (each within the scatter of the next).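

In this assay, among the compounds shown here, the exchange of 4-methoxyphenyl for 2,6-dichlorophenyl on a carbonyl carbon whose other neighbour is an amide-type nitrogen gives a 1.3-fold higher number from compound 2 to compound 3 (0.12 log units; within the scatter) and is the first direct reading of a change at this place, which the comparison of compound 1 and compound 2 could not give. Both groups have 8 heavy atoms and one six-membered aromatic ring of carbon only, but the leaving group has 1 hydrogen-bond acceptor and the entering group has 0, so on this one pair, exchanging the methoxy oxygen and its acceptor for two chlorines does not separate the two compounds. No measurement shown explains why their numbers stay so close.

The compounds shown leave open whether a group without an aromatic ring on this carbonyl carbon, such as a cyclohexyl ring or a short alkyl chain, would also stay within the scatter of compound 2. As far as these compounds go, it is equally open whether a carboxylic acid or an amine added to the aromatic ring at this place would produce a step beyond the scatter.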